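The compounds below may be only part of what the source reports. "The series", "measured", "known", "first", "only" and "open" are said of these compounds alone.

For the measured compounds named here, compound 3 `Cc1oc2c([C@H]3CCN(C)C[C@H]3O)c(O)cc(O)c2c(=O)c1C(O)c1ccccc1Br` has been tested in a functional assay on PC-3 cells (Homo sapiens) for inhibition, read by MTT assay, with a stated time of 48 h, tested at 10 uM (on this read-out higher numbers stand for more inhibition of growth at the one concentration tested and lower numbers for less inhibition of growth), and gives 45%, the highest of the three numbers measured so far. Compound 1 `CCN(CC)Cc1c(O)c([C@H]2CCN(C)C[C@H]2O)c2oc(C)cc(=O)c2c1O` gives 2% in this assay, and compound 2 `Cc1cc(=O)c2c(O)c(CN3CC(O)CC3C(=O)O)c(O)c([C@H]3CCN(C)C[C@H]3O)c2o1` gives 0%; both of these gaps to compound 3 lie beyond the scatter. Compound 4 `Cc1oc2c([C@H]3CCN(C)C[C@H]3O)c(O)cc(O)c2c(=O)c1C(O)c1ccc(F)cc1` differs from compound 3 in one place: 4-fluorophenyl in place of 2-bromophenyl on a saturated chain carbon bound to an aromatic carbon and an oxygen on a saturated carbon. Going by the values given here, the only measured step, a number 2 percentage points lower from compound 1 to compound 2 (within the scatter), alters a different part of the shared core and says nothing about exchanging one substituted phenyl for another, so no measured step bears on this change. Without such guidance, the step is expected to be a number 10 percentage points lower from compound 3 to compound 4 (within the scatter), which may well stay within the scatter. Compound 4 is therefore estimated at 35%, in a range from 10% to 60%.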

Compound 4, percent growth inhibition at one concentration: 0%
Estimate against measurement, compound 4: 35 percentage points above; the measured number lies below the stated range.
By their numbers in this assay, from the lowest: compounds 2, 4 and 1 (each within the scatter of the next); then compound 3.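

Placing 4-fluorophenyl in place of 2-bromophenyl on this saturated chain carbon gives a number 45 percentage points lower from compound 3 to compound 4 (beyond the scatter) in this assay. For the compounds shown here, the two groups differ only in their halogen and where it sits on the ring, so at this place, growth inhibition is sensitive to that small difference, which the earlier compounds could not show. No evidence at hand explains the size of this step.

The compounds shown leave open whether the halogen itself or its place on the ring matters more. A 2-fluorophenyl or 4-bromophenyl group on this carbon would separate the two.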